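The source may hold more compounds than are shown below. What is called first, only, known or untested is meant among the compounds shown, and "the series" means these compounds.

Measured so far:
compound 1 `COc1cccc(-c2n[nH]c(-c3ccc(Cl)cc3C)n2)c1` — 0.04 mg/kg
compound 2 `COc1cccc(-c2n[nH]c(-c3ccc(C)cc3C)n2)c1` — 0.04 mg/kg
compound 3 `COc1cccc(-c2n[nH]c(-c3cc(Cl)ccc3C)n2)c1` — 0.35 mg/kg

Read-out throughout is a functional assay on the whole organism (Cricetulus griseus) with Cricetinae gen. sp. as the target; a lower number here means that less compound is needed, a higher number that more compound is needed for the effect. Compound 3 stands highest of the three; its nearest neighbour is compound 1, and the difference between the two cores is not broken down here. Compound 4 `COc1cccc(-c2n[nH]c(-c3cc(C)ccc3C)n2)c1` is not yet measured.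

The change from compound 1 to compound 2 is methyl in place of chloro on an aromatic carbon. Its step: no change at the digits printed from compound 1 to compound 2 (within the scatter).

From compound 3 to compound 4 the change is methyl in place of chloro on an aromatic carbon. It is the same kind of change, not the same: in compound 1 the aromatic carbon is meta to a methyl group and para to a large group, in compound 3 it is meta to a large group and para to a methyl group.

Because no change at the digits printed from compound 1 to compound 2 (within the scatter) showed no change, the step from compound 3 to compound 4 is expected to be no change at the digits printed from compound 3 to compound 4 (within the scatter). Compound 4 is estimated at 0.35 mg/kg, between 0.15 mg/kg and 0.8 mg/kg.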

Compound 4, dose for half-maximal effect: 2.5 mg/kg
For compound 4 the middle estimate is 7.1-fold (0.85 log units) below the measured one; measured number above the stated range.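

In this assay, methyl in place of chloro does not carry over unchanged from one core to the other: the same change on two cores in this assay, no change at the digits printed (within the scatter) from compound 1 to compound 2 and a 7.1-fold higher number (0.85 log units; beyond the scatter) from compound 3 to compound 4, 7.1-fold (0.85 log units) apart, beyond the scatter of two such steps. With the change meta to a large group and para to a methyl group, the result is a 7.1-fold higher number from compound 3 to compound 4 (0.85 log units; beyond the scatter), so the flat result on the core of compound 1 cannot be used as a guide for this position. These two pairs show that the outcome depends on the setting of the change, but they do not show what produces the difference or how the change would behave on a further core.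

Only chloro and methyl are shown at this place. As far as these compounds go, how an amine, a carboxylic acid or a longer chain would fare there remains open.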